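From hydroxy to methoxy on compound 1

A few compounds are considered here, and "the series" means these few. Any claim that something is new, unique, unknown or untested is made for them only; others in the source may bear on it.

Going by the values given here, in a functional assay on A498 cells (Homo sapiens) for antiproliferative activity, read by sulforhodamine B assay, with a stated time of 48 h (on this read-out lower numbers stand for stronger inhibition of growth and higher numbers for weaker inhibition of growth), compound 1 (`O=C(NCCCNc1cc(-c2cn(-c3ccccc3)nc2-c2cccc(O)c2)ccn1)Nc1ccc(F)cc1`) gives 4960 nM and compound 2 (`O=C(NCCCNc1cc(-c2cn(-c3ccccc3)nc2-c2cccc(O)c2)ccn1)Nc1cccc(C(F)(F)F)c1`) gives 7180 nM as its reading, so compound 1 sits within the scatter of the only other measured compound. Compound 3 (`COc1cccc(-c2nn(-c3ccccc3)cc2-c2ccnc(NCCCNC(=O)Nc3ccc(F)cc3)c2)c1`) differs from compound 1 by methyl in place of hydrogen on an oxygen on an aromatic ring and so carries 3-methoxyphenyl in place of 3-hydroxyphenyl. Among the compounds with values here, the one measured step is a 1.4-fold higher number from compound 1 to compound 2 (0.16 log units; within the scatter) and it lies on an amide-type nitrogen, so no measurement tests this oxygen directly. The expected step is a 1.2-fold higher number from compound 1 to compound 3 (0.08 log units; within the scatter) and stays within the scatter, with no firm direction. For compound 3 the estimated value is 6000 nM with 2500 nM to 15000 nM as the expected range.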

Compound 3, concentration for total growth inhibition: 31400 nM
Compound 3: the middle estimate sits 5.2-fold (0.72 log units) below what was measured, outside the stated range (above it).
By their numbers in this assay, from the lowest: compounds 1 and 2 (each within the scatter of the next); then compound 3.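

Methoxy in place of hydroxy gives a 6.3-fold higher number from compound 1 to compound 3 (0.80 log units; beyond the scatter) in this assay, a step beyond the scatter, whereas the one earlier step, on an amide-type nitrogen, stayed within it. This oxygen on an aromatic ring is therefore a place where adding a single methyl weakens growth inhibition in this series. Nothing available accounts for this loss. The compounds shown leave open how other groups would read here, such as an amine or a carboxylic acid in place of the hydroxy, or a longer chain on the oxygen.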